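Aryl urea variation on a shared core: compound 4

A few compounds are considered here, and "the series" means these few. Any claim that something is new, unique, unknown or untested is made for them only; others in the source may bear on it.

Working notes. The series keeps one core and varies the aryl group on an amide-type nitrogen. Compound 1 `O=C(Nc1cccc(CNc2nccnc2Cl)c1)Nc1ccccc1Cl` carries a 2-chlorophenyl there; in a functional assay on HepG2 cells (Homo sapiens) for antiproliferative activity, read by MTT assay, with a stated time of 48 h (a lower number here means a stronger inhibitor, a higher number a weaker inhibitor), compound 1 gives 8560 nM. Compound 2 `O=C(Nc1cccc(CNc2nccnc2Cl)c1)Nc1ccc(Cl)cc1Br` carries a 2-bromo-4-chlorophenyl, and in this assay compound 2 gives 6720 nM. Compound 3 `O=C(Nc1cccc(CNc2nccnc2Cl)c1)Nc1ccc(F)c(Cl)c1` carries a 3-chloro-4-fluorophenyl, and in this assay compound 3 gives 6750 nM, which places it second highest of the three numbers, with compound 2 nearest and compound 1 furthest, both gaps within the scatter.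

The steps measured so far are all small: a 1.3-fold lower number from compound 1 to compound 2 (0.11 log units; within the scatter), a 1.3-fold lower number from compound 1 to compound 3 (0.10 log units; within the scatter) and a 1.0-fold higher number from compound 2 to compound 3 (0.00 log units; within the scatter). None is beyond the scatter, so the three aryl groups tried cannot be told apart on these numbers.

Compound 4 `Cc1cccc(NC(=O)Nc2cccc(CNc3nccnc3Cl)c2)c1` is the next member; the change from compound 3 is 3-methylphenyl in place of 3-chloro-4-fluorophenyl on an amide-type nitrogen. It again exchanges one aryl group on the amide-type nitrogen for another, and the three measured steps of that kind all stayed within the scatter. For compound 4 the expectation in this assay is therefore no step beyond the scatter, that is a 1.1-fold higher number from compound 3 to compound 4 (0.05 log units; within the scatter). Compound 4 is thus estimated at 7500 nM, with a range from 3500 nM to 16000 nM.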

Compound 4, half-maximal inhibitory concentration: 11200 nM
Beside the measured number, compound 4's estimate is 1.5-fold (0.17 log units) below it; the range from low to high includes it.
By their numbers in this assay, from the lowest: compounds 2, 3, 1 and 4 (each within the scatter of the next).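

In this assay, within the data shown here, compound 4 brings the first aryl group on the amide-type nitrogen with no halogen, and its 3-methylphenyl stays within the scatter of all three halogen-bearing groups (a 1.7-fold higher number from compound 3 to compound 4 (0.22 log units; within the scatter); a 1.7-fold higher number from compound 2 to compound 4 (0.22 log units; within the scatter); a 1.3-fold higher number from compound 1 to compound 4 (0.12 log units; within the scatter)). The earlier compounds shown here varied only the halogens and their places on the ring, whereas this exchange of 3-chloro-4-fluorophenyl for 3-methylphenyl removes both halogens and still gives no step beyond the scatter, so the four aryl groups cannot be told apart on these numbers. No further measurement bears on this result, and the numbers alone offer no explanation for it.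

Still open, going by these compounds, is whether any group at this position gives a step beyond the scatter, for instance a phenyl ring carrying an amine or a carboxylic acid, or a longer alkyl chain in place of the methyl. On these data alone, all four compounds keep the shared core and the urea carbonyl, so it also remains open whether the aryl group would matter as little with a change elsewhere in the molecule.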